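Adding a Carboxy Side Chain to Compound 1

A few compounds are considered here, and "the series" means these few. Any claim that something is new, unique, unknown or untested is made for them only; others in the source may bear on it.

Compound 1 `O=S(=O)(c1cccc(C(F)(F)F)c1)N1CCc2ccc(-c3cc(F)cc(OC(F)F)c3)cc21`: 0.19 h
Compound 2 `O=C(O)CCc1cc2ccc(-c3cc(F)cc(OC(F)F)c3)cc2n1S(=O)(=O)c1cccc(C(F)(F)F)c1`: > 2.41 h
Compound 3 `O=C(O)CCCC1CN(S(=O)(=O)c2cccc(C(F)(F)F)c2)c2cc(-c3cc(F)cc(OC(F)F)c3)ccc21`: 0.57 h

In an ADME assay on microsomes from liver (Mus musculus) for metabolic stability, read by LC-MS, using NADPH, with a stated time of 60 min, tested at 1 uM (a higher number here means that the compound lasts longer, a lower number that the compound disappears faster), compound 1 gives 0.19 h, the lower of the two exact numbers. The nearest value belongs to compound 3, at 0.57 h. The entry for compound 2, > 2.41 h, is a limit and not a number.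

Compound 4 `O=C(O)C1CCN(C(=O)CC2Cc3ccc(-c4cc(F)cc(OC(F)F)c4)cc3N2S(=O)(=O)c2cccc(C(F)(F)F)c2)CC1` is still to be measured. It differs from compound 1 by ((4-carboxypiperidin-1-yl)carbonyl)methyl in place of hydrogen on a saturated ring carbon. For the measured compounds named here, one measured step bears on this change, which is 3-carboxypropyl in place of hydrogen on a saturated ring carbon. That step is modest, at a 3.0-fold higher number from compound 1 to compound 3 (0.48 log units; beyond the scatter). Since the new group also carries a carboxy function, a rise of similar size is expected in this assay, though this rests on a single step. The expected step is a 3.7-fold higher number from compound 1 to compound 4 (0.57 log units; beyond the scatter). For compound 4 the estimated half-life is 0.7 h, with an expected range from 0.25 h to 2.2 h.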

Compound 4, half-life: 0.502 h
The estimate for compound 4 lay 1.4-fold (0.14 log units) above the measured number, within the range that was stated.
By their numbers in this assay, from the lowest: compound 1; then compounds 4 and 3 (each within the scatter of the next). At a limit, above all of these: compound 2.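

With ((4-carboxypiperidin-1-yl)carbonyl)methyl in place of hydrogen on a saturated ring carbon next to the ring nitrogen, this assay shows a 2.6-fold higher number from compound 1 to compound 4 (0.42 log units; beyond the scatter). This is a second carboxy-bearing group on the saturated ring, after a 3.0-fold higher number from compound 1 to compound 3 (0.48 log units; beyond the scatter), so a rise beyond the scatter is no longer tied to the 3-carboxypropyl chain alone. The new group also holds a six-membered non-aromatic ring and a further carbonyl, and its step is still modest.

The compounds shown do not separate the carboxylic acid from the rest of the side chain, so it remains open whether a methyl ester or a primary amine on this ring carbon would give a step of similar size. No measurement given here offers a reason for either step.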